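Methyl on the Aryl Ring: Cytotoxicity in Amide Quinolinones

The source may hold more compounds than are shown below. What is called first, only, known or untested is meant among the compounds shown, and "the series" means these compounds.

Compound 1, `Cc1cccc2cc(CN(Cc3ccco3)C(=O)c3ccccc3)c(=O)[nH]c12`: > 67100 nM
Compound 2, `Cc1ccc(C(=O)N(Cc2ccco2)Cc2cc3cccc(C)c3[nH]c2=O)cc1`: 9200 nM
Compound 3, `Cc1ccc2[nH]c(=O)c(CN(Cc3ccccc3)C(=O)c3ccco3)cc2c1`: > 67100 nM

In an ADME assay on MT2 cells (Homo sapiens) for cytotoxicity, read by XTT assay, with a stated time of 4 days (on this read-out lower numbers stand for higher toxicity in this test and higher numbers for lower toxicity in this test), compound 1 gives > 67100 nM, which is a limit of the assay and not a number. Compound 2 carries methyl in place of hydrogen on an aromatic carbon, and the result is an at least 7.2-fold lower number from compound 1 to compound 2 (0.86 log units; beyond the scatter). Compound 3 gives > 67100 nM in this assay , again a limit. The difference between the core of compound 3 and that of compound 1 is not broken down here. Compound 4, `Cc1ccc(CN(Cc2cc3cc(C)ccc3[nH]c2=O)C(=O)c2ccco2)cc1`, carries the same change as compound 2, (methyl in place of hydrogen on an aromatic carbon), with the place described in the same words. Resting on the measured step for compound 2, the expected step is an at least 2.6-fold lower number from compound 3 to compound 4 (0.42 log units; beyond the scatter). Since two of the three values sit at the limit of > 67100 nM in this assay, at which 2 of the 3 values shown sit, a limit for compound 4 remains likely. The estimate for compound 4 in this assay is 25000 nM, between 7000 nM and 67100 nM.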

Compound 4, half-maximal cytotoxic concentration: > 19800 nM
Compound 4 ended at the assay's limit (the forecaster's own chance of this, stated with the estimate: 50%); the middle value is on the limit's open side.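

Compound 4 gives > 19800 nM, a limit and not a number. Among the compounds shown here, compound 3 also sits at a limit, and no step from compound 3 to compound 4 can be read. On these data alone, whether 4-methylbenzyl in place of benzyl lowers the number at all stays open.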